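Methyl branching on the acid chain: compound 3 to compound 4

The source may hold more compounds than are shown below. What is called first, only, known or untested is meant among the compounds shown, and "the series" means these compounds.

Measured so far in an assay on membranes from lung (Cavia porcellus) for binding affinity to cysteinyl leukotriene receptor (Homo sapiens); a lower number here means a stronger inhibitor, a higher number a weaker inhibitor:
compound 1 `CC(CCC(=O)O)Cc1cccc(OCc2ccc3ccccc3n2)c1`, compound 1 gives 140 nM
compound 2 `c1cc(OCCCc2nnn[nH]2)cc(OCc2ccc3ccccc3n2)c1`, compound 2 gives 42 nM
compound 3 `CC(CCCc1cccc(OCc2ccc3ccccc3n2)c1)C(=O)O`, compound 3 gives 85 nM

Compound 3 stands second highest of the three numbers in this assay; its nearest neighbour is compound 1, with the step of a 1.6-fold lower number from compound 1 to compound 3 (0.22 log units; within the scatter) lying within the scatter, while the step of a 2.0-fold higher number from compound 2 to compound 3 (0.31 log units; beyond the scatter) is modest and beyond the scatter.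

Compound 4 `CC(Cc1cccc(OCc2ccc3ccccc3n2)c1)CC(C)C(=O)O` has not yet been measured. It differs from compound 3 by methyl in place of hydrogen on a saturated chain carbon bound to two saturated chain carbons; read one bond further out, the chain goes from 3-carboxybutyl to 3-carboxy-1-methylbutyl.

For the measured compounds named here, the only step that bears on this is a 1.6-fold lower number from compound 1 to compound 3 (0.22 log units; within the scatter), where moving a single methyl along the same acid chain stayed within the scatter. The present change adds a methyl on that chain rather than moving one, so no step beyond the scatter is expected in this assay, in either direction; the expected step is a 1.2-fold higher number from compound 3 to compound 4 (0.07 log units; within the scatter). Compound 4 is therefore estimated at 100 nM, with a range of 40 nM to 250 nM.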

Compound 4, inhibition constant: 24 nM
Beside the measured number, compound 4's estimate is 4.2-fold (0.62 log units) above it; the measured number lies below the stated range.
By their numbers in this assay, from the lowest: compounds 4 and 2 (each within the scatter of the next); then compounds 3 and 1 (each within the scatter of the next).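

In this assay, methyl in place of hydrogen on a saturated chain carbon bound to two saturated chain carbons gives a 3.5-fold lower number from compound 3 to compound 4 (0.55 log units; beyond the scatter) and so moves the number beyond the scatter, unlike the shift of a single methyl along the chain in a 1.6-fold lower number from compound 1 to compound 3 (0.22 log units; within the scatter). Methyl in place of hydrogen on a saturated chain carbon bound to a carbonyl carbon and a saturated chain carbon gives a 5.8-fold lower number from compound 1 to compound 4 (0.77 log units; beyond the scatter) as well, so compound 4, which carries both methyls, stands apart from each singly branched acid, while a 1.8-fold lower number from compound 2 to compound 4 (0.24 log units; within the scatter) leaves the 4-carboxy-2-methylpentyl and 3-(1H-tetrazol-5-yl)propoxy chains unresolved. No measurement at hand accounts for these steps.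

From the compounds shown here alone, whether an ethyl on either branching carbon would lower the number further remains open. So does the effect of a 1H-tetrazol-5-yl group in place of the carboxylic acid on the doubly branched chain.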